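Urea Tail Change on a Shared Core in Compound 3

The source may hold more compounds than are shown below. What is called first, only, known or untested is meant among the compounds shown, and "the series" means these compounds.

Measured compounds:
compound 1 `O=C(NCc1ccc(C(=O)N2CCCCc3ccccc32)c(Cl)c1)Nc1c(F)cccc1F`: 40 nM
compound 2 `Cc1cc(C(=O)N2CCCCc3ccccc32)ccc1CNC(=O)NCC(N)=O`: 210 nM

In a functional assay on HEK293 cells for agonist activity at Vasopressin V2 receptor (Homo sapiens), read by a luciferase reporter and cAMP accumulation (a higher number here means that more compound is needed for the effect, a lower number that less compound is needed), compound 2 gives the higher of the two numbers, and compound 1 gives a number that lies beyond the scatter below it. Compound 3 `Cc1cc(C(=O)N2CCCCc3ccccc32)ccc1CNC(=O)N1CCC[C@@H]1C(=O)N(C)C` has not yet been measured; it differs from compound 2 by 2-(dimethylcarbamoyl)pyrrolidin-1-yl in place of (carbamoylmethyl)amino on a carbonyl carbon. For the measured compounds named here, no measured pair shows this change, so the step from compound 2 to compound 3 is expected to be modest and in either direction, and a small gain is estimated: a 1.6-fold lower number from compound 2 to compound 3 (0.21 log units; within the scatter). For compound 3 the expected value is 130 nM, between 30 nM and 600 nM.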

Compound 3, half-maximal effective concentration: 380 nM
Estimate against measurement, compound 3: 2.9-fold (0.47 log units) below; measured number inside the range.
By their numbers in this assay, from the lowest: compound 1; then compounds 2 and 3 (each within the scatter of the next).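

In this assay, putting 2-(dimethylcarbamoyl)pyrrolidin-1-yl in place of (carbamoylmethyl)amino on a carbonyl carbon gives a 1.8-fold higher number from compound 2 to compound 3 (0.26 log units; within the scatter), so this position accepts a group with a five-membered ring, 10 heavy atoms in place of 5 and 0 hydrogen-bond donors in place of 2 without a step beyond the scatter. No supporting data bear on why this is so. The compounds shown leave open whether the ring, the dimethylcarbamoyl group or the defined stereocentre matters most, and how a carboxylic acid on the pyrrolidine ring would read.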